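Swapping the Thiadiazole for an Aminotriazole on the Chromone Core

This account rests on a few compounds, and the source may have more. Where it says the series, first, only, none or still open, it means among the compounds named here.

Measured so far:
compound 1, `Cc1nnc(SCc2cc(=O)c3cc(Cl)ccc3o2)s1`: > 25000 nM
compound 2, `Cc1nnc(SCc2coc3ccccc3c2=O)s1`: 430 nM
compound 3, `Cc1nnc(SCc2coc3ccc(Cl)cc3c2=O)s1`: 7600 nM

In a functional assay on LM7 cells (Homo sapiens) for cytotoxicity, read by MTT assay, with a stated time of 72 h (a lower number here means a stronger inhibitor, a higher number a weaker inhibitor), compound 2 gives 430 nM, the lowest of the two numbers reported. Among the measured compounds shown here, its nearest neighbour is compound 3, which in this assay gives 7600 nM; the step of an 18-fold higher number from compound 2 to compound 3 (1.25 log units; beyond the scatter) is the only one measured between compounds that differ in a single place. For compound 1 this assay reports only a limit, > 25000 nM, and not a number (the limit of > 25000 nM in this assay, at which 1 of the 3 values shown sits).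

Compound 4, `Nc1nc(SCc2coc3ccccc3c2=O)n[nH]1`, has not yet been measured. It differs from compound 2 in one place: 5-amino-1H-1,2,4-triazol-3-yl in place of 5-methyl-1,3,4-thiadiazol-2-yl on a sulfur. For the measured compounds named here, none of the measured steps concerns this kind of exchange; the only step in hand, the chloro for hydrogen change between compound 2 and compound 3, touches a different part of the molecule and so says little about a swap of the group on the sulfur. Going by the values given here, with no direct precedent, a moderate step is expected for compound 4, most likely toward a somewhat higher number, as a 3.5-fold higher number from compound 2 to compound 4 (0.54 log units; beyond the scatter). Compound 4 is therefore estimated at 1500 nM, with a range from 300 nM to 8000 nM.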

Compound 4, half-maximal inhibitory concentration: 16900 nM
For compound 4 the middle estimate is 11-fold (1.05 log units) below the measured one, outside the stated range (above it).
By their numbers in this assay, from the lowest: compound 2; then compound 3; then compound 4. At a limit, above all of these: compound 1.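

In this assay the group on the sulfur proves to be a sensitive place: a 39-fold higher number from compound 2 to compound 4 (1.59 log units; beyond the scatter) is a large loss for the 5-amino-1H-1,2,4-triazol-3-yl in place of the 5-methyl-1,3,4-thiadiazol-2-yl. The two groups are each a five-membered aromatic ring with the same number of heavy atoms, so matching these counts does not preserve the value of compound 2. The earlier compounds showed a large step only for chloro on an aromatic carbon, whereas this result shows that compound 2 also loses much by a change on the sulfur, and nothing shown gives a reason for this step.

The compounds shown leave open whether the step follows the ring exchange or the amine, since a methyl in place of that amine on the triazole would separate the two. From the compounds shown here alone, it also remains open whether a simple amide or a carboxylic acid on the sulfur chain would be tolerated at this place.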